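Swapping a Sulfonamide for a Nitrophenoxy Group

The compounds below may be only part of what the source reports. "The series", "measured", "known", "first", "only" and "open" are said of these compounds alone.

Three compounds have been measured in a functional assay on PANC-1 cells (Homo sapiens) for inhibition, read by MTT assay, with a stated time of 24 h, tested at 10 uM; a lower number here means less inhibition, a higher number more inhibition at the concentration tested (going by the name of the read-out):
Compound 1, `CC(C)=CCC/C(C)=C/CC1Cc2c(O)cc(=O)n(CCCO)c2CC1(C)C`, gives 28.7%.
Compound 2, `CC(C)=CCC1Cc2c(OCCCNS(=O)(=O)c3ccc(Cl)cc3)cc(=O)n(CCCO)c2CC1(C)C`, gives 24.7%.
Compound 3, `COc1ccc(OCCCOc2cc(=O)n(CCCO)c3c2CC(CC=C(C)C)C(C)(C)C3)cc1`, gives 47.7%.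

Compound 2 stands lowest of the three numbers, with compound 1 within the scatter of it and compound 3 clearly above it. Compound 4, `CC(C)=CCC1Cc2c(OCCCOc3ccc([N+](=O)[O-])cc3)cc(=O)n(CCCO)c2CC1(C)C`, is not yet measured. It differs from compound 2 by 4-nitrophenoxy in place of ((4-chlorophenyl)sulfonyl)amino on a saturated chain carbon, three bonds along the chain from an oxygen on an aromatic ring. Among the measured compounds shown here, one measured step bears on this: a number 23 percentage points higher from compound 2 to compound 3 (beyond the scatter), a modest rise. Since a number 23 percentage points higher from compound 2 to compound 3 (beyond the scatter) came from putting another aryloxy group in place of the same sulfonamide at the same place, a rise of similar size is expected for compound 4, though with a wide range, as the nitro-bearing ring is not the methoxy-bearing one. The expected step is a number 17.3 percentage points higher from compound 2 to compound 4 (beyond the scatter). Compound 4 is estimated at 42%, with a range from 24% to 60%.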

Compound 4, a percentage reported as inhibition, at one concentration (the size of the read-out at that concentration, not a potency): 47.5%
Estimate against measurement, compound 4: 5.5 percentage points below; the measured number falls inside the stated range.
By their numbers in this assay, from the lowest: compounds 2 and 1 (each within the scatter of the next); then compounds 4 and 3 (each within the scatter of the next).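

A second aryloxy group in place of ((4-chlorophenyl)sulfonyl)amino gives a number 22.8 percentage points higher from compound 2 to compound 4 (beyond the scatter), so the rise at this place on the chain is not confined to compound 3. Nitro in place of methoxy on an aromatic carbon gives a number 0.2 percentage points lower from compound 3 to compound 4 (within the scatter) in this assay, so these two ring groups cannot be told apart here. No measured evidence explains either result.

As far as these compounds go, whether the ring itself matters stays open: an amine or a carboxylic acid at the end of the same chain would test this. A longer chain carrying 4-nitrophenoxy would show whether the chain length matters.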